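The source may hold more compounds than are shown below. What is called first, only, known or untested is meant among the compounds shown, and "the series" means these compounds.

Measured so far:
Compound 1, `COC[C@@H](C)n1cc(Cl)nc(Nc2cc(C)c(OC)nc2C)c1=O`, gives 14 nM.
Compound 2, `Cc1cc(Nc2nc(Cl)cn([C@H](C)C3CC3)c2=O)c(C)nc1OC(F)F`, gives 0.3 nM.

In an assay on frontal cortex for displacement of a labelled ligand from corticotropin-releasing factor receptor 1 (Rattus norvegicus) (on this read-out lower numbers stand for stronger inhibition and higher numbers for weaker inhibition), compound 2 stands at the lowest of the two numbers recorded; compound 1 is its nearest neighbour, and the gap between the two is well beyond the usual scatter of repeated measurements. Compound 1 and compound 2 differ from each other in more than one place, so no single-change step can be read from the measured pair.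

Compound 3, `COC[C@@H](C)n1cc(Cl)nc(Nc2cc(C)c(OC(F)F)nc2C)c1=O`, has not yet been measured in this assay. Its change from compound 2 is methoxymethyl in place of cyclopropyl on a saturated chain carbon bound to an aromatic nitrogen and a saturated chain carbon; one bond further out, this reads as 1-cyclopropylethyl giving way to 1-(methoxymethyl)ethyl. Within the data shown here, no measured step isolates this exchange, so its size cannot be taken from the data. Because the starting point is 0.3 nM, compound 2 leaves room in either direction, and some loss seems the more likely outcome here. For compound 3 a step of a 5.0-fold higher number from compound 2 to compound 3 (0.70 log units; beyond the scatter) is expected, a modest move toward weaker inhibition. Compound 3 is therefore estimated at 1.5 nM, with a plausible range from 0.4 nM to 6 nM.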

Compound 3, half-maximal inhibitory concentration: 1.6 nM
Compound 3: the middle estimate sits 1.1-fold (0.03 log units) below what was measured, within the range that was stated.
By their numbers in this assay, from the lowest: compound 2; then compound 3; then compound 1.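

Compound 3 links the two earlier compounds, which differ in more than one place, so in this assay each of their differences can now be read on its own. On the saturated chain carbon bound to an aromatic nitrogen and a saturated chain carbon, methoxymethyl in place of cyclopropyl gives a 5.3-fold higher number from compound 2 to compound 3 (0.73 log units; beyond the scatter), a modest move toward weaker inhibition with the difluoromethyl group on the oxygen unchanged. With 1-(methoxymethyl)ethyl unchanged, difluoromethyl in place of methyl on an oxygen on an aromatic ring gives an 8.8-fold lower number from compound 1 to compound 3 (0.94 log units; beyond the scatter), a modest move toward stronger inhibition, so these two single changes act in opposite directions on this read-out. No supporting data bear on why either change has the effect seen.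

The compounds shown leave open whether the exchange of cyclopropyl for methoxymethyl would have the same size with methyl rather than difluoromethyl on the oxygen. They also leave open how a longer chain or an amine at the same saturated chain carbon would read in this assay.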